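This account rests on a few compounds, and the source may have more. Where it says the series, first, only, none or still open, it means among the compounds named here.

Compounds measured in an assay for inhibition of 3-hydroxy-3-methylglutaryl-coenzyme A reductase (Rattus norvegicus); on this read-out lower numbers stand for stronger inhibition and higher numbers for weaker inhibition:

Compound 1, `C[C@H]1C=C2C=C[C@H](C)[C@H](CCC3C[C@@H](O)CC(=O)O3)[C@H]2[C@@H](OCc2ccc(Cl)cc2)C1`, gives 170 nM.
Compound 2, `C[C@H]1C=C2C=C[C@H](C)[C@H](CCC3C[C@@H](O)CC(=O)O3)[C@H]2[C@@H](OCc2ccccc2)C1`, gives 27 nM.
Compound 3, `C=CCC(=O)O[C@H]1C[C@@H](C)C=C2C=C[C@H](C)[C@H](CCC3C[C@@H](O)CC(=O)O3)[C@H]21`, gives 2.9 nM.

Compound 3 stands lowest of the three in this assay: its nearest neighbour is compound 2, a step of a 9.3-fold lower number from compound 2 to compound 3 (0.97 log units; beyond the scatter), and the furthest is compound 1, a step of a 59-fold lower number from compound 1 to compound 3 (1.77 log units; beyond the scatter). Compound 4, `CO[C@H]1C[C@@H](C)C=C2C=C[C@H](C)[C@H](CCC3C[C@@H](O)CC(=O)O3)[C@H]21`, has not been measured. It differs from compound 3 in one place: methyl in place of allylcarbonyl on an oxygen on a saturated carbon.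

The two steps that bear on this change both replace a group on that same oxygen. Going a 59-fold lower number from compound 1 to compound 3 (1.77 log units; beyond the scatter) and a 9.3-fold lower number from compound 2 to compound 3 (0.97 log units; beyond the scatter), the allylcarbonyl gave a lower number than either benzyl group, and among the benzyl groups a 6.3-fold lower number from compound 1 to compound 2 (0.80 log units; beyond the scatter) separates the two. For the measured compounds named here, no measured compound carries a methyl here, so the size of the step is uncertain; since both substitutes for allylcarbonyl in this set gave higher numbers, a higher number is expected for compound 4 as well, of a size between the two measured steps. Compound 4 is therefore estimated at 40 nM, within a range from 10 nM to 160 nM, which would be a step of a 14-fold higher number from compound 3 to compound 4 (1.14 log units; beyond the scatter).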

Compound 4, half-maximal inhibitory concentration: 2810 nM
Compound 4: the middle estimate sits 70-fold (1.85 log units) below what was measured; the measured number lies above the stated range.
By their numbers in this assay, from the lowest: compound 3; then compound 2; then compound 1; then compound 4.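

In this assay, for the compounds shown here, the change from (allylcarbonyl)oxy to methoxy is far larger than anything the earlier compounds suggested, at a 970-fold higher number from compound 3 to compound 4 (2.99 log units; beyond the scatter), and it places the methyl group above both benzyl groups rather than among them. Taking the aromatic ring off the benzyl groups also raises the number, with a 100-fold higher number from compound 2 to compound 4 (2.02 log units; beyond the scatter) for the unsubstituted one and a 17-fold higher number from compound 1 to compound 4 (1.22 log units; beyond the scatter) for the 4-chloro one, so an aromatic ring on this chain carbon gives lower numbers than hydrogen even though the chloro substituent gave a higher number than hydrogen on that ring. The order across these four groups on this oxygen therefore does not follow the count of heavy atoms, since the one-carbon methyl gives the highest number, and nothing available explains why the numbers fall in this order.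

From the compounds shown here alone, what remains open is whether the carbonyl or the allyl chain of the ester matters more, which an allyl ether set against an acetyl ester would begin to separate. Also open, going by these compounds, is where the free hydroxyl, an ethyl ether or a longer ester such as hexanoyl would fall on this oxygen.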